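A few compounds are considered here, and "the series" means these few. Any claim that something is new, unique, unknown or untested is made for them only; others in the source may bear on it.

Measured compounds:
Compound 1, `O=c1cc(Cn2cc(CCO)nn2)c2ccc(O)cc2o1`, in a functional assay on HeLa cells (Homo sapiens) for inhibition, read by MTT assay, with a stated time of 72 h (a lower number here means a stronger inhibitor, a higher number a weaker inhibitor), gives only a limit, > 100000 nM.
Compound 2, `O=c1cc(Cn2cc(CCCO)nn2)c2ccc(O)cc2o1`, in this assay gives 90200 nM.
Compound 3, `CCCCCCCCc1cn(Cc2cc(=O)oc3cc(O)ccc23)nn1`, in this assay gives 35100 nM.

Compound 3 holds the lowest of the two numbers recorded; the nearest is compound 2, and the step of a 2.6-fold lower number from compound 2 to compound 3 (0.41 log units; beyond the scatter) lies beyond the scatter. Compound 1 sits at the limit of > 100000 nM in this assay, at which 1 of the 3 values shown sits, and supplies no number, so its step of an at least 2.8-fold lower number from compound 1 to compound 3 (0.45 log units; beyond the scatter) is read as a floor only. The step of an at least 1.1-fold lower number from compound 1 to compound 2 (0.04 log units; that floor lies within the scatter) is within the scatter.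

Compound 4, `O=c1cc(Cn2cc(CCc3ccccc3)nn2)c2ccc(O)cc2o1`, is not yet measured. Its change from compound 3 is phenyl in place of hexyl on a saturated chain carbon, two bonds along the chain from an aromatic carbon. For the measured compounds named here, both measured steps that reach compound 3 replace a hydroxy on the chain with a longer carbon chain, and both give lower numbers; none of them swaps a chain for an aromatic ring, so there is no direct precedent for this change. The phenyl keeps the same count of carbon atoms as the hexyl and removes no donor or acceptor, so the step is expected to stay close to compound 3, within the scatter or slightly lower.

For compound 4 in this assay the expected value is 30000 nM, in the range 10000 nM to 90000 nM, the expected step being a 1.2-fold lower number from compound 3 to compound 4 (0.07 log units; within the scatter).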

Compound 4, half-maximal inhibitory concentration: 35100 nM
Compound 4: the middle estimate sits 1.2-fold (0.07 log units) below what was measured, within the range that was stated.
By their numbers in this assay, from the lowest: compounds 3 and 4 (each within the scatter of the next); then compound 2. At a limit, above all of these: compound 1.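

In this assay, phenyl in place of hexyl gives no change at the digits printed from compound 3 to compound 4 (within the scatter), so on a saturated chain carbon, two bonds along the chain from an aromatic carbon, this read-out does not separate the aromatic ring from the open chain. The earlier compounds showed lower numbers only with a longer carbon chain; phenyl in place of hydroxymethyl now gives a 2.6-fold lower number from compound 2 to compound 4 (0.41 log units; beyond the scatter), so among the compounds shown, an open chain is not required for a step of this size. Phenyl in place of hydroxy gives an at least 2.8-fold lower number from compound 1 to compound 4 (0.45 log units; beyond the scatter), and this step reads as a floor only, as compound 1 stands at a limit of the assay: the limit of > 100000 nM in this assay, at which 1 of the 4 values shown sits.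

Still open, on these data alone, is whether the numbers reached with hexyl and phenyl mark the best this position can give, or whether a longer chain, a chloro-substituted phenyl or a pyridine ring would go lower. Also open, as far as these compounds go, is how a chain ending in an amine or a carboxylic acid would compare with the hydroxy-ended chains of compound 1 and compound 2.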